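The source may hold more compounds than are shown below. What is called first, only, known or untested is meant among the compounds shown, and "the series" means these compounds.

Acylguanidine series, followed for growth inhibition in a functional assay on Hs 683 cells (Homo sapiens) for inhibition, read by MTT assay, with a stated time of 72 h; a lower number here means a stronger inhibitor of growth, a higher number a weaker inhibitor of growth. Compound 1 `CC(C)=CC(=O)NC(=N)N` returns only a limit in this assay, > 100000 nM; this is the limit of > 100000 nM in this assay, at which 1 of the 3 values shown sits. Compound 2 `C=C1CCCC(C)(C)[C@@H]1CC/C(C)=C/C(=O)NC(=N)NC(=O)C=C(C)C` gives 18100 nM in this assay. Compound 3 `CC(C)=CCC/C(C)=C/C(=O)NC(=N)NC(=O)/C=C(\C)CCC=C(C)C` gives 32700 nM in this assay, the higher of the two numbers, with compound 2 its nearest and the gap within the scatter. Compound 4 `CC(C)=CCC/C(C)=C/CC/C(C)=C/C(=O)NC(=N)NC(=O)/C=C(\C)CCC=C(C)C` carries the change 3-methylbut-2-en-1-yl in place of hydrogen on a saturated chain carbon bound to a double-bonded chain carbon and has not yet been measured in this assay. Within the data shown here, no pair among compounds 1, 2 and 3 differs in one place, so the change has no measured precedent here. The expected step is a 2.2-fold lower number from compound 3 to compound 4 (0.34 log units; beyond the scatter), about the size of the scatter and toward a lower number if anything. The estimate for compound 4 in this assay is 15000 nM, between 4000 nM and 50000 nM.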

Compound 4, concentration for 50% growth inhibition: 37400 nM
Compound 4: the middle estimate sits 2.5-fold (0.40 log units) below what was measured; low and high end bracket the measured number.
By their numbers in this assay, from the lowest: compounds 2, 3 and 4 (each within the scatter of the next, the first and the last beyond it). At a limit, above all of these: compound 1.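

With 3-methylbut-2-en-1-yl in place of hydrogen on a saturated chain carbon bound to a double-bonded chain carbon, this assay gives the series its first single-place step: a 1.1-fold higher number from compound 3 to compound 4 (0.06 log units; within the scatter). At this position, the 3-methylbut-2-en-1-yl group therefore does not separate the two compounds beyond the scatter. Nothing shown accounts for this result.

Going by these compounds, whether a longer chain, or an amine or carboxylic acid at the chain end, would behave alike remains open. So does the same change on the other acyl chain.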